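A few compounds are considered here, and "the series" means these few. Any claim that something is new, unique, unknown or untested is made for them only; others in the source may bear on it.

Measured so far:
compound 1, `C=C(C)[C@@H]1CC=C(C)/C(=N/NC(=O)Nc2nnc(-c3ccccc3)o2)C1`: 300 mg/kg
compound 2, `C=C(C)[C@@H]1CC=C(C)/C(=N/NC(=O)Nc2nnc(-c3ccc(OC)cc3)o2)C1`: 300 mg/kg
compound 3, `C=C(C)[C@@H]1CC=C(C)/C(=N/NC(=O)Nc2nnc(-c3ccc([N+](=O)[O-])cc3)o2)C1`: 300 mg/kg

All three were tested in a functional assay on the whole organism (strain Swiss albino) with Mus musculus as the target, with a stated time of 4 h; on this read-out lower numbers stand for an effect already at smaller amounts and higher numbers for an effect only at larger amounts of compound. Compound 3 stands level with compounds 1 and 2 at the digits shown, since no change at the digits printed from compound 1 to compound 2 (within the scatter), no change at the digits printed from compound 1 to compound 3 (within the scatter) and no change at the digits printed from compound 2 to compound 3 (within the scatter) all lie within the scatter. Compound 4, `C=C(C)[C@@H]1CC=C(C)/C(=N/NC(=O)Nc2nnc(-c3ccc(C)cc3)o2)C1`, is not yet measured. It differs from compound 3 in one place: methyl in place of nitro on an aromatic carbon, so 4-nitrophenyl becomes 4-methylphenyl. For the measured compounds named here, the steps that bear on this are the earlier exchanges at the same aromatic carbon, hydrogen, methoxy and nitro, none of which moved the dose in this assay. No step beyond the scatter is therefore expected for the methyl either. Compound 4 is estimated at 300 mg/kg, with a range from 150 mg/kg to 600 mg/kg, which means an expected step of no change at the digits printed from compound 3 to compound 4 (within the scatter).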

Compound 4, minimum effective dose: 300 mg/kg
Beside the measured number, compound 4's estimate shows no gap at the digits printed; the measured number falls inside the stated range.
By their numbers in this assay, from the lowest: compounds 1, 2, 3 and 4 (each within the scatter of the next).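

In this assay, methyl now joins hydrogen, methoxy and nitro at this aromatic carbon, and the new readings show no change at the digits printed from compound 3 to compound 4 (within the scatter) and no change at the digits printed from compound 2 to compound 4 (within the scatter) and no change at the digits printed from compound 1 to compound 4 (within the scatter). The set at this position now includes a group made of carbon and hydrogen alone, and the dose still stays level. Nothing measured here offers a reason for this flat result.

On these data alone, what an amine, a carboxylic acid or a longer chain at this aromatic carbon would do stays open. So does whether changes elsewhere on the shared core would shift the dose.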